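A few compounds are considered here, and "the series" means these few. Any claim that something is new, unique, unknown or untested is made for them only; others in the source may bear on it.

Measured so far:
compound 1, `O=C(O)c1cn(C2CC2)c2c(F)c(N3CCNCC3)c(F)cc2c1=O`: 47 ug/mL
compound 2, `O=C(O)c1cn(C2CC2)c2c(Cl)c(N3CCNCC3)c(F)cc2c1=O`: 43 ug/mL
compound 3, `CC1CN(c2c(F)cc3c(=O)c(C(=O)O)cn(C4CC4)c3c2F)CC(C)N1`: 150 ug/mL

All three compounds were tested in a functional assay on V79 cells (Cricetulus griseus) for cytotoxicity, read by colony formation; on this read-out lower numbers stand for stronger inhibition and higher numbers for weaker inhibition. Compound 1 and compound 2 share one core and differ in a single place: chloro in place of fluoro on an aromatic carbon. That exchange made a 1.1-fold lower number from compound 1 to compound 2 (0.04 log units; within the scatter), so the two values cannot be told apart with confidence.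

Compound 3 carries a different core. The difference between the two cores is 3,5-dimethylpiperazin-1-yl in place of piperazin-1-yl on an aromatic carbon. This change gave a 3.2-fold higher number from compound 1 to compound 3 (0.50 log units; beyond the scatter), and compound 3 therefore stands with the highest number of the three measured compounds.

Compound 4, `CC1CN(c2c(F)cc3c(=O)c(C(=O)O)cn(C4CC4)c3c2Cl)CC(C)N1`, has not yet been tested. It differs from compound 3 in one place: chloro in place of fluoro on an aromatic carbon. Among the compounds with values here, this is the same kind of change as the one from compound 1 to compound 2, but the surroundings are not identical: around the changed carbon in compound 1 there is a piperazin-1-yl group, while in compound 3 there is a 3,5-dimethylpiperazin-1-yl group.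

The expectation for compound 4 rests on compound 1 and compound 2, whose exchange gave a 1.1-fold lower number from compound 1 to compound 2 (0.04 log units; within the scatter). On that basis the step from compound 3 to compound 4 is expected to be a 1.1-fold lower number from compound 3 to compound 4 (0.03 log units; within the scatter), in this assay staying within the usual scatter. Compound 4 is thus estimated at 140 ug/mL, with a likely range from 70 ug/mL to 280 ug/mL, in this assay.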

Compound 4, half-maximal inhibitory concentration: 140 ug/mL
For compound 4 middle estimate and measured number coincide at the digits printed; the measured number falls inside the stated range.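

In this assay, chloro in place of fluoro on an aromatic carbon gave a 1.1-fold lower number from compound 3 to compound 4 (0.03 log units; within the scatter), so on this core too the two values cannot be told apart, and the step matches the one seen on the core of compound 1: the same change on two cores in this assay, a 1.1-fold lower number (0.04 log units; within the scatter) from compound 1 to compound 2 and a 1.1-fold lower number (0.03 log units; within the scatter) from compound 3 to compound 4, 1.0-fold (0.01 log units) apart, within the scatter of two such steps

The piperazine change carries over as well, since 3,5-dimethylpiperazin-1-yl in place of piperazin-1-yl gave a 3.3-fold higher number from compound 2 to compound 4 (0.51 log units; beyond the scatter), and this step matches the one seen with fluoro in place of chloro: the same change on two cores in this assay, a 3.2-fold higher number (0.50 log units; beyond the scatter) from compound 1 to compound 3 and a 3.3-fold higher number (0.51 log units; beyond the scatter) from compound 2 to compound 4, 1.0-fold (0.01 log units) apart, within the scatter of two such steps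

Within these four compounds the two changes therefore act independently, with the halogen exchange making no clear difference and the two added methyl groups on the piperazine accounting for the whole shift, but this rests on just two pairs for each change in a single assay, and it neither explains the shift nor shows that the agreement would hold on other cores.

The compounds shown leave open whether the same carbon would behave alike with a bromo, a methoxy or a plain hydrogen in place of the halogen. They also leave open whether other amines, such as 4-methylpiperazin-1-yl or 3-aminopyrrolidin-1-yl, would shift the number as 3,5-dimethylpiperazin-1-yl does.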